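The source may report more compounds than this note shows. Statements on the series, on what has been measured and on what is new or still open speak of the compounds shown alone.

Notes on the series. Going by the values given here, in an assay on HEK293 cells for inhibition of Voltage-dependent T-type calcium channel subunit alpha-1G (Homo sapiens) (a higher number here means a weaker inhibitor, a lower number a stronger inhibitor), compound 1 `O=C(CC1c2ccccc2N=C(N2CCCCC2)N1c1ccccc1)NCc1ccc(NS(=O)(=O)c2ccc(F)cc2)cc1` gives 110 nM, while compound 2 `O=C(CC1c2ccccc2N=C(N2CCCCC2)N1c1ccccc1)NCc1ccccc1` gives 1160 nM; the single measured step, an 11-fold higher number from compound 1 to compound 2 (1.02 log units; beyond the scatter), shows how strongly the distal part of the amide side chain can bear on the read-out. Compound 3 `NCCCCCNC1=Nc2ccccc2C(CC(=O)NCc2ccccc2)N1c1ccc(-c2ccccc2)cc1` gives 130 nM, close to compound 1 and well apart from compound 2. The next compound, compound 4 `COC(=O)CC1c2ccccc2N=C(NCCCCCN)N1c1ccc(-c2ccccc2)cc1`, differs from compound 3 by methoxy in place of benzylamino on a carbonyl carbon. Among the compounds with values here, no measured step touches this exact position; the only precedent is the same side chain, where an 11-fold higher number from compound 1 to compound 2 (1.02 log units; beyond the scatter) was seen, which argues that cutting it back should cost potency. For compound 4 a weaker inhibitor is therefore expected, a step of a 12-fold higher number from compound 3 to compound 4 (1.06 log units; beyond the scatter). The estimate for compound 4 is 1500 nM, with a range from 400 nM to 6000 nM.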

Compound 4, half-maximal inhibitory concentration: 560 nM
Beside the measured number, compound 4's estimate is 2.7-fold (0.43 log units) above it; the measured number falls inside the stated range.
By their numbers in this assay, from the lowest: compounds 1 and 3 (each within the scatter of the next); then compound 4; then compound 2.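

Methoxy in place of benzylamino on the carbonyl carbon gives a 4.3-fold higher number from compound 3 to compound 4 (0.63 log units; beyond the scatter) in this assay, the first measured step at this position. The loss is modest: with the benzylamino group gone, including its aromatic ring and hydrogen-bond donor, compound 4 still registers at 560 nM. No measurement at hand accounts for this step.

Which part of benzylamino carries the difference remains open. A methylamino group or a plain amine on the same carbonyl carbon, or a carboxylic acid in place of the methyl ester, would help separate the ring from the amide hydrogen.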